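Swapping benzyl for cyclopentyl on the amide nitrogen

The source may report more compounds than this note shows. Statements on the series, on what has been measured and on what is new or still open speak of the compounds shown alone.

Measured in a functional assay on L1210 cells (Mus musculus) for inhibition; a higher number here means a weaker inhibitor, a lower number a stronger inhibitor:
- compound 1 `CCC(C)C(NC(=O)NO)C(=O)NCc1ccccc1` gives 126000 nM
- compound 2 `CCC(C)C(NC(=O)n1nnc2ccccc21)C(=O)NCc1ccccc1` gives 123000 nM

Compound 2 holds the lowest of the two numbers in this assay, yet its nearest neighbour is compound 1, and the two values lie within the usual scatter of each other, so neither can be called the stronger inhibitor. For the measured compounds named here, the only measured step, a 1.0-fold lower number from compound 1 to compound 2 (0.01 log units; within the scatter), concerns a change on the carbonyl carbon and leaves the rest of the molecule untouched.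

Compound 3 `CCC(C)C(NC(=O)n1nnc2ccccc21)C(=O)NC1CCCC1` is not yet measured. It differs from compound 2 by cyclopentyl in place of benzyl on an amide-type nitrogen. Going by the values given here, no measured step touches this part of the molecule, so nothing seen so far speaks for a shift in either direction in this assay. The expectation is therefore a number close to that of compound 2, with a wide margin for the unknown.

Compound 3 is estimated at 130000 nM in this assay, with a plausible range from 40000 nM to 400000 nM, which means an expected step of a 1.1-fold higher number from compound 2 to compound 3 (0.02 log units; within the scatter).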

Compound 3, half-maximal inhibitory concentration: 102000 nM
For compound 3 the middle estimate is 1.3-fold (0.11 log units) above the measured one, and the stated range covers the measured number.
By their numbers in this assay, from the lowest: compounds 3, 2 and 1 (each within the scatter of the next).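

Replacing benzyl with cyclopentyl on the amide-type nitrogen, a part of the molecule the earlier step left untouched, gives a 1.2-fold lower number from compound 2 to compound 3 (0.08 log units; within the scatter) in this assay. On this nitrogen, then, a six-membered aromatic ring of carbon only can give way to a five-membered non-aromatic ring of carbon only, with two heavy atoms fewer in the group, and no difference between compound 2 and compound 3 can be read from the numbers. Nothing at hand offers an explanation for this result.

Both steps shown stay within the scatter, so these compounds do not tell whether any change at this position can move the number by a clear margin in this assay. Also open, on these data alone, is what an amine, a carboxylic acid or a longer chain would do in place of cyclopentyl on this nitrogen, and whether cyclopentyl would read the same when paired with the carbonyl substituent of compound 1.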